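Trifluoromethoxy for Trifluoromethyl on Two Related Cores

The source may hold more compounds than are shown below. What is called first, only, known or untested is meant among the compounds shown, and "the series" means these compounds.

Compound 1 `CC(O)(CSc1ccc(C(F)(F)F)cc1)C(=O)Nc1ccc(S(F)(F)(F)(F)F)cc1` and compound 2 `CC(O)(CSc1ccc(OC(F)(F)F)cc1)C(=O)Nc1ccc(S(F)(F)(F)(F)F)cc1` share one core, while compound 3 `CC(O)(CSc1ccccc1C(F)(F)F)C(=O)Nc1cccc(S(F)(F)(F)(F)F)c1` has the same atoms joined differently; the difference between the two cores is not broken down here. In a functional assay on DU-145 cells (Homo sapiens) for antiproliferative activity, read by propidium iodide staining, with a stated time of 96 h (a lower number here means a stronger inhibitor, a higher number a weaker inhibitor), compound 1 gives 28800 nM, compound 2 gives 12500 nM, and compound 3 gives 15800 nM. The change trifluoromethoxy in place of trifluoromethyl on an aromatic carbon produced a 2.3-fold lower number from compound 1 to compound 2 (0.36 log units; beyond the scatter). Compound 4 `CC(O)(CSc1ccccc1OC(F)(F)F)C(=O)Nc1cccc(S(F)(F)(F)(F)F)c1` is not yet measured and arises from compound 3 by trifluoromethoxy in place of trifluoromethyl on an aromatic carbon. The two changes are the same kind of change but not the same: in compound 2 the entering group is para to a large group, in compound 4 ortho to a large group. The measured step of a 2.3-fold lower number from compound 1 to compound 2 (0.36 log units; beyond the scatter) is the only basis for the expectation. Compound 4 is therefore expected to show a 2.0-fold lower number from compound 3 to compound 4 (0.30 log units; within the scatter). Compound 4 is estimated at 8000 nM, between 3000 nM and 20000 nM.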

Compound 4, half-maximal inhibitory concentration: 17500 nM
The estimate for compound 4 lay 2.2-fold (0.34 log units) below the measured number, and the stated range covers the measured number.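

In this assay, the step on the second core is a 1.1-fold higher number from compound 3 to compound 4 (0.04 log units; within the scatter), so trifluoromethoxy and trifluoromethyl cannot be told apart there, where the entering group stands ortho to a large group. Set beside the earlier step, this result does not differ from it beyond what repeated measurement allows: the same change on two cores in this assay, a 2.3-fold lower number (0.36 log units; beyond the scatter) from compound 1 to compound 2 and a 1.1-fold higher number (0.04 log units; within the scatter) from compound 3 to compound 4, 2.6-fold (0.41 log units) apart, within the scatter of two such steps The two steps therefore neither show that the change carries over from one core to the other nor show that its outcome depends on the core, and two pairs of compounds cannot settle the question.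

The compounds shown leave open how a group other than these two, such as a nitrile or an amine, would read on the same aromatic carbon. They also leave open how this change would read on any further core.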